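Para substituent changes on the aryl group of compound 1

This account rests on a few compounds, and the source may have more. Where it says the series, first, only, none or still open, it means among the compounds named here.

Compound 1 `CCC1=C(O)c2c(oc(-c3ccc(C(C)C)cc3)cc2=O)C(CC)(CC)C1=O` is the reference point of this small set. Among the compounds with values here, in a functional assay on KBVIN cells (Homo sapiens) for antiproliferative activity, read by sulforhodamine B assay, with a stated time of 3 days (on this read-out higher numbers stand for an effect only at larger amounts of compound and lower numbers for an effect already at smaller amounts), compound 1 gives 1.08 uM, the lowest of the three numbers known so far. Two single-point variations at the same aromatic carbon have both been measured. Compound 2 `CCCOc1ccc(-c2cc(=O)c3c(o2)C(CC)(CC)C(=O)C(CC)=C3O)cc1` gives 29.2 uM in this assay, and compound 3 `CCC1=C(O)c2c(oc(-c3ccc(CBr)cc3)cc2=O)C(CC)(CC)C1=O` gives 27.9 uM; the corresponding steps are a 27-fold higher number from compound 1 to compound 2 (1.43 log units; beyond the scatter) and a 26-fold higher number from compound 1 to compound 3 (1.41 log units; beyond the scatter), while between the two altered compounds there is a 1.0-fold lower number from compound 2 to compound 3 (0.02 log units; within the scatter).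

Compound 4 `CCC1=C(O)c2c(oc(-c3ccc(COC)cc3)cc2=O)C(CC)(CC)C1=O` has not yet been measured. It differs from compound 1 by methoxymethyl in place of isopropyl on an aromatic carbon. The two measured steps that bear on this change, a 27-fold higher number from compound 1 to compound 2 (1.43 log units; beyond the scatter) and a 26-fold higher number from compound 1 to compound 3 (1.41 log units; beyond the scatter), both replace the isopropyl group at this position and both give large losses of roughly equal size, regardless of whether the entering group carries an oxygen or a bromine. On that basis a loss of similar magnitude is expected for compound 4 as well, since the methoxymethyl group again removes the isopropyl group from the same aromatic carbon. The step from compound 1 to compound 4 is therefore estimated as a 14-fold higher number from compound 1 to compound 4 (1.14 log units; beyond the scatter). Compound 4 is expected to give about 15 uM in this assay, with a plausible range from 4 uM to 50 uM.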

Compound 4, concentration for half-maximal effect: 3.4 uM
Compound 4: middle estimate off by 4.4-fold (0.64 log units), on the high side; the whole stated range lies above it.
By their numbers in this assay, from the lowest: compound 1; then compound 4; then compounds 3 and 2 (each within the scatter of the next).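

In this assay, within the data shown here, the replacement of isopropyl need not cost as much as the earlier compounds suggested: methoxymethyl at the same aromatic carbon gives a 3.1-fold higher number from compound 1 to compound 4 (0.50 log units; beyond the scatter) and the step is only modest, although compound 1 still holds the lowest number of the four. The size of the loss depends on the entering group and not only on the departure of isopropyl: there is an 8.2-fold lower number from compound 3 to compound 4 (0.91 log units; beyond the scatter) with methoxy in place of bromo on the saturated chain carbon bound to an aromatic carbon, and an 8.6-fold lower number from compound 2 to compound 4 (0.93 log units; beyond the scatter) with methoxymethyl in place of propoxy, so an oxygen in the entering group does not decide the outcome by itself, as compound 2 shows. Nothing at hand explains these differences.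

Going by these compounds, how hydroxymethyl, ethoxymethyl or aminomethyl would compare with methoxymethyl at this aromatic carbon remains open. On these data alone, a plain propyl chain at the same place would separate the contribution of the chain from that of its oxygen, and that comparison also remains open.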